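A few compounds are considered here, and "the series" means these few. Any claim that something is new, unique, unknown or untested is made for them only; others in the source may bear on it.

Compound 3 `CC(C)CCn1nc(C2CCC2)c(O)c(C2=NS(=O)(=O)c3cc(NS(C)(=O)=O)ccc3N2)c1=O` is one of three compounds of a shared core examined in an ADME assay on Huh-7 cells (Homo sapiens) for cytotoxicity, with a stated time of 72 h; a higher number here means that more compound is tolerated, a lower number that less compound is tolerated. In this assay compound 3 reaches only the limit > 33000 nM, which is a limit of the assay and not a number. Compound 1 `CCS(=O)(=O)Nc1ccc2c(c1)S(=O)(=O)N=C(c1c(O)c(-c3cccs3)nn(CCC(C)C)c1=O)N2` likewise shows only the limit > 33000 nM in this assay. For compound 2 `CC(C)CCn1nc(-c2cccs2)c(O)c(C2=NS(=O)(=O)c3cc(S(=O)(=O)N(C)C)ccc3N2)c1=O` this assay gives "not determined" (no result reported). For the measured compounds named here, compound 3 therefore stands at the same limit as compound 1, the point described by the limit of > 33000 nM in this assay, at which 2 of the 3 values shown sit, and no compound here has a number to compare with.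

Compound 4 `CC(C)CCn1nc(CCC(F)(F)F)c(O)c(C2=NS(=O)(=O)c3cc(NS(C)(=O)=O)ccc3N2)c1=O` differs from compound 3 in one place: 3,3,3-trifluoropropyl in place of cyclobutyl on an aromatic carbon. The 3,3,3-trifluoropropyl enters on an aromatic carbon of a six-membered aromatic ring with 2 nitrogen, ortho to a hydroxy group, where the cyclobutyl leaves. Going by the values given here, no measured step between two compounds is available to say how such a change moves this assay, so the expectation rests on compound 3 and compound 1 sitting at the limit.

Compound 4 is expected to be tolerated much as compound 3 is, with an estimated step that the limit leaves unreadable from compound 3 to compound 4 of no size beyond the scatter. In this assay compound 4 is estimated at 35000 nM, with a range from 15000 nM to 100000 nM, and most likely again only a limit will be reported.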

Compound 4, half-maximal cytotoxic concentration: > 33000 nM
Compound 4: only a limit was reported; the forecaster's own chance of this, stated with the estimate: 80%; the middle value is on the limit's open side.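

Compound 3 and compound 4 both give only a limit in this assay, so no step can be read between them. The compounds shown leave open at what concentration any of them would reach half-maximal cytotoxicity, and whether 3,3,3-trifluoropropyl in place of cyclobutyl changes it.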